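Methylamino in Place of Diacetylamino on the Pyrimidine Core

The source may hold more compounds than are shown below. What is called first, only, known or untested is meant among the compounds shown, and "the series" means these compounds.

Three compounds have been measured in a functional assay on the whole organism for inhibition, with Rattus norvegicus as the target, with stated times of 1 h and 3.5 h, at a dose of 100 mg/kg by the oral route; on this read-out higher numbers stand for more inhibition at the one dose given (going by the name of the read-out) and lower numbers for less inhibition:

Compound 1 `Cc1ncc2c(n1)CCC(C(C)(C)C)C2`: < 5%. For compound 1 this is a limit of the assay, not a number.
Compound 2 `CC(C)(C)c1nc(N)ncc1-c1ccccc1`: 46%
Compound 3 `CC(=O)N(C(C)=O)c1ncc(-c2ccccc2)c(C(C)(C)C)n1`: 22%

Among the two numbers, compound 3 is the lower one, and the only measured step is a number 24 percentage points lower from compound 2 to compound 3 (beyond the scatter), a drop beyond the scatter. Compound 4 `CNc1ncc(-c2ccccc2)c(C(C)(C)C)n1` differs from compound 3 by methylamino in place of diacetylamino on an aromatic carbon. This step undoes the diacetyl part of that earlier change while keeping one methyl on the nitrogen, so some recovery toward compound 2 is expected, though not necessarily all the way. Compound 4 is therefore estimated to rise by a number 13 percentage points higher from compound 3 to compound 4 (beyond the scatter), giving about 35%, expected between 15% and 55%.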

Compound 4, a percentage reported as inhibition, in the whole organism at one dose (the size of the read-out at that dose, not a potency): 37%
Compound 4: the middle estimate sits 2 percentage points below what was measured, within the range that was stated.
By their numbers in this assay, from the lowest: compound 3; then compounds 4 and 2 (each within the scatter of the next). At a limit, below all of these: compound 1.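

Methylamino in place of diacetylamino, between two ring nitrogen atoms, gives a number 15 percentage points higher from compound 3 to compound 4 (beyond the scatter), so the read-out at this position follows what is carried on the nitrogen. With one methyl on that nitrogen, the other comparison is a number 9 percentage points lower from compound 2 to compound 4 (within the scatter), so amino and methylamino cannot be told apart on this read-out. Nothing shown gives a reason for either step.

Open, going by these compounds, is how a single acetyl group on this nitrogen, as in acetylamino, would read. Dimethylamino and ethylamino are equally open.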